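The compounds below may be only part of what the source reports. "The series", "measured", "known", "first", "only" and "open" are said of these compounds alone.

Measured in a functional assay on HepG2 cells (Homo sapiens) for antiproliferative activity, read by MTT assay, with a stated time of 72 h; a lower number here means a stronger inhibitor, a higher number a weaker inhibitor:
- compound 1 `CCOC(=O)c1csc2nc(CN3CCN(C)CC3)c(-c3ccc(Br)cc3)n12`: 82700 nM
- compound 2 `CC(=O)NNC(=O)c1csc2ncc(-c3ccc(C)cc3)n12`: 63600 nM
- compound 3 `CCC(=O)NNC(=O)c1csc2ncc(-c3ccc(C)cc3)n12`: 7340 nM

Among these three, compound 3 has the lowest number in this assay, at 7340 nM, and so is the most potent of the set. The next compound to consider, compound 4 `CCCC(=O)NNC(=O)c1csc2ncc(-c3ccc(C)cc3)n12`, differs from it only in the chain of the acyl group, where propanoyl becomes propylcarbonyl: methyl in place of hydrogen on a saturated chain carbon, two bonds along the chain from a carbonyl carbon.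

For the measured compounds named here, only one measured step bears on this change. It is an 8.7-fold lower number from compound 2 to compound 3 (0.94 log units; beyond the scatter), which came from methyl in place of hydrogen on a saturated chain carbon bound to a carbonyl carbon. Going by the values given here, compound 1 differs from the others in more than one place and offers no comparable step. The new methyl in compound 4 sits further along the chain, and a single step cannot show whether the trend continues. A change in the same direction is therefore expected, toward a lower number, but smaller than the measured step and possibly within the scatter. The estimated step is a 1.8-fold lower number from compound 3 to compound 4 (0.26 log units; within the scatter). For compound 4 the expected value is 4000 nM, with an estimated range from 1300 nM to 14000 nM.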

Compound 4, half-maximal inhibitory concentration: 26800 nM
Compound 4: middle estimate off by 6.7-fold (0.83 log units), on the low side, and the stated range ends below it.
By their numbers in this assay, from the lowest: compound 3; then compound 4; then compounds 2 and 1 (each within the scatter of the next).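

In this assay, the same added methyl acts in opposite directions at the two places on the acyl chain: on a saturated chain carbon bound to a carbonyl carbon it gave an 8.7-fold lower number from compound 2 to compound 3 (0.94 log units; beyond the scatter) and the chain did not simply improve from there, since two bonds along the chain from a carbonyl carbon it gives a 3.7-fold higher number from compound 3 to compound 4 (0.56 log units; beyond the scatter) and so turns the number back up. Part of the earlier gain survives, as ethyl in place of hydrogen on the carbon bound to the carbonyl carbon still leaves a 2.4-fold lower number from compound 2 to compound 4 (0.38 log units; beyond the scatter) and so the number does not fall steadily with chain length across these three compounds, with the propanoyl chain of compound 3 lowest among them. Nothing measured here accounts for this reversal.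

The compounds shown stop at the propylcarbonyl chain, so it stays open whether a longer chain, a branched chain, or a chain ending in an amine or a carboxylic acid would raise the number further or bring it back down. On these data alone, it also stays open whether the same reversal would appear on the core of compound 1.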